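The source may hold more compounds than are shown below. What is called first, only, known or untested is meant among the compounds shown, and "the series" means these compounds.

Measured so far in a functional assay on MCF7 cells (Homo sapiens) for inhibition, read by XTT assay, with a stated time of 48 h; on this read-out lower numbers stand for stronger inhibition and higher numbers for weaker inhibition:
- compound 1, `C/C=C(\COC(=O)c1ccccc1)C(=O)c1ccc(OC)cc1`: compound 1 gives 29800 nM
- compound 2, `COc1ccc(C(=O)/C(=C/c2ccc(Cl)cc2Cl)CC(C)OC(C)=O)cc1`: compound 2 reports only a limit of the assay, > 100000 nM
- compound 3, `C=C(C(=O)c1ccc(OC)cc1)C(OC(C)=O)c1ccc(Cl)cc1Cl`: compound 3 gives 8300 nM

Compound 3 holds the lowest of the two numbers in this assay; the nearest number, that of compound 1, stands above it by a gap beyond the usual scatter. Compound 2 sits at the limit of > 100000 nM in this assay, at which 1 of the 3 values shown sits, so it gives no number to compare. Going by the values given here, no pair of measured compounds differs in a single place, so no step has been measured.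

Compound 4, `C=C(C(=O)c1ccc(OC)cc1)C(OC(C)=O)C1CCCCC1`, is not yet measured. It differs from compound 3 by cyclohexyl in place of 2,4-dichlorophenyl on a saturated chain carbon bound to a double-bonded chain carbon and an oxygen next to a carbonyl group. The remainder of the core is unchanged. Among the compounds with values here, no measured step shows what this exchange does, so the size of the step in this assay is open; the working expectation is a moderate weakening, probably beyond the scatter, rather than a gain. Compound 4 is therefore expected to give 22000 nM, with a range from 6000 nM to 80000 nM. The expected step of a 2.7-fold higher number from compound 3 to compound 4 (0.42 log units; beyond the scatter) is thus a loss of inhibition of moderate size.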

Compound 4, half-maximal inhibitory concentration: 14000 nM
Compound 4: the middle estimate sits 1.6-fold (0.20 log units) above what was measured; low and high end bracket the measured number.
By their numbers in this assay, from the lowest: compounds 3 and 4 (each within the scatter of the next); then compound 1. At a limit, above all of these: compound 2.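

In this assay, cyclohexyl in place of 2,4-dichlorophenyl on a saturated chain carbon bound to a double-bonded chain carbon and an oxygen next to a carbonyl group gives a 1.7-fold higher number from compound 3 to compound 4 (0.23 log units; within the scatter), the first single-place step available in the series. This place therefore accepts a non-aromatic ring of carbon only as well as an aromatic one: in this pair, neither the aromatic ring nor the two chlorine atoms is needed to keep inhibition at this level. The measured data bear on the size of this step but offer no ground for assigning it a cause.

The compounds shown leave open whether the aromatic ring and the chlorine atoms each matter on their own, a question that a plain phenyl at this place would address. Going by these compounds, it also remains open how far this tolerance extends, since the two rings compared here are both six-membered carbon rings carrying no hydrogen-bond donor or acceptor, and a dimethylamine or a carboxylic acid on a cyclohexyl ring at the same place would test that limit.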